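A few compounds are considered here, and "the series" means these few. Any claim that something is new, unique, unknown or untested is made for them only; others in the source may bear on it.

Compound 1 `N#Cc1ccc2c(Oc3ccccc3OCCn3ccc(=O)[nH]c3=O)cccc2c1` — > 100000 nM
Compound 2 `N#Cc1ccc2c(Oc3ccccc3OCCn3ccc(=O)[nH]c3=O)cc(F)cc2c1` — > 100000 nM
Compound 3 `N#Cc1ccc2c(Oc3ccc(Cl)cc3OCCn3ccc(=O)[nH]c3=O)cc(F)cc2c1` — 18000 nM

In an ADME assay on MT2 cells (Homo sapiens) for cytotoxicity, read by MTT assay (a higher number here means that more compound is tolerated, a lower number that less compound is tolerated), compound 2 stands at > 100000 nM, which is a limit of the assay and not a number. Compound 1 likewise ends at a limit, > 100000 nM. Only compound 3 returns a number, 18000 nM. Two of the three values thus sit at the limit of > 100000 nM in this assay, at which 2 of the 3 values shown sit, so compound 2 cannot be placed more closely than the top of what was tested.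

Compound 4 `N#Cc1ccc2c(Oc3ccccc3OCCn3ccc(=O)[nH]c3=O)cc(Cl)cc2c1` differs from compound 2 by chloro in place of fluoro on an aromatic carbon. Within the data shown here, two measured steps bear on this change. The step that the two limits leave unreadable from compound 1 to compound 2 brings in the very fluoro that now leaves, but with both ends at the limit its size is not readable. The step of an at least 5.5-fold lower number from compound 2 to compound 3 (0.74 log units; beyond the scatter) shows that a chloro entering on an aromatic carbon lowered the tolerated concentration by a clear margin. Trading one halogen for another is expected to move the number less than that, so compound 4 is expected to stay near compound 2 or drop only modestly, an at least 1.6-fold lower number from compound 2 to compound 4 (0.22 log units; that floor lies within the scatter). Compound 4 is therefore estimated at 60000 nM, between 20000 nM and 150000 nM, with a fair chance that this assay again reports only a limit.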

Compound 4, half-maximal cytotoxic concentration: 24000 nM
The estimate for compound 4 lay 2.5-fold (0.40 log units) above the measured number, and the stated range covers the measured number.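

In this assay, chloro in place of fluoro at this position gives an at least 4.1-fold lower number from compound 2 to compound 4 (0.61 log units; beyond the scatter), so the identity of the halogen here changes the read-out, which the unreadable step from hydrogen to fluoro could not show. Set against the hydrogen of the core of compound 1, the same chloro gives an at least 4.1-fold lower number from compound 1 to compound 4 (0.61 log units; beyond the scatter), so fluoro and hydrogen cannot be told apart at the top of the tested range, while chloro brings the number down from there. Chloro on this ring of the fused system therefore lowers the tolerated concentration, as chloro on the other aromatic ring did in compound 3, and both steps lie beyond the scatter: the same change on two cores in this assay, an at least 5.5-fold lower number (0.74 log units; beyond the scatter) from compound 2 to compound 3 and an at least 4.1-fold lower number (0.61 log units; beyond the scatter) from compound 1 to compound 4; the limit leaves it open whether they differ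

Going by these compounds, the true size of each step stays open, since each one starts from a limit and is only a floor: the limit of > 100000 nM in this assay, at which 2 of the 4 values shown sit. Also open is whether the drop follows chloro alone or extends to other groups at this position, such as bromo, methyl, methoxy or an amine.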